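The compounds below may be only part of what the source reports. "The series", "measured", "known", "first", "only" and "open" are said of these compounds alone.

Measured so far:
Compound 1, `Cn1nc(Cc2nnc(SCCCCCCCC(=O)Nc3ccc(Cl)cc3Cl)n2CCCO[Si](C)(C)C(C)(C)C)c2ccccc2c1=O`: in an assay on NK92 cells for inhibition of interleukin-15 (Homo sapiens), read by AlphaScreen, with stated times of 30 min and 1 h (on this read-out higher numbers stand for weaker inhibition and lower numbers for stronger inhibition), compound 1 gives > 30000 nM, which is a limit of the assay rather than a number.
Compound 2, `CN(C)CCCn1c(Cc2nn(C)c(=O)c3ccccc23)nnc1SCCCCCCCC(=O)Nc1ccc(Cl)cc1Cl`: in this assay compound 2 gives > 30000 nM, again a limit of the assay.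
Compound 3, `Cn1c(Cc2nn(CCCO[Si](C)(C)C(C)(C)C)c(=O)c3ccccc23)nnc1SCCCCCCCC(=O)Nc1ccc(Cl)cc1Cl`: in this assay compound 3 gives > 30000 nM, also a limit of the assay.

Compound 1 and compound 2 differ by a group of 3 heavy atoms (2 carbon, 1 nitrogen; no ring) in place of a group of 8 heavy atoms (6 carbon, 1 oxygen, 1 silicon; no ring), on a saturated chain carbon, three bonds along the chain from an aromatic nitrogen. The result is a step that the two limits leave unreadable from compound 1 to compound 2, unreadable because both ends sit at the limit of > 30000 nM in this assay, at which 3 of the 3 values shown sit. Compound 3 carries the same atoms as compound 1 joined differently; the difference between the two cores is not broken down here.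

Compound 4, `CN(C)CCCn1nc(Cc2nnc(SCCCCCCCC(=O)Nc3ccc(Cl)cc3Cl)n2C)c2ccccc2c1=O`, is not yet measured. For the measured compounds named here, it differs from compound 3 by a group of 3 heavy atoms (2 carbon, 1 nitrogen; no ring) in place of a group of 8 heavy atoms (6 carbon, 1 oxygen, 1 silicon; no ring), on a saturated chain carbon, three bonds along the chain from an aromatic nitrogen, the same change as the one from compound 1 to compound 2, made at the same place.

From compound 3 to compound 4 the step expected is a number no higher from compound 3 to compound 4 (the limit leaves the size open); this rests on the fact that the same change from compound 1 to compound 2 left both at the limit of > 30000 nM in this assay, at which 3 of the 3 values shown sit. Compound 3 itself sits at > 30000 nM, a limit of the assay. Compound 4 is therefore estimated to give 30000 nM in this assay, most likely as a limit again, with an expected range from 10000 nM to 100000 nM.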

Compound 4, half-maximal inhibitory concentration: > 30000 nM
Compound 4 ended at the assay's limit; the forecaster's own chance of this, stated with the estimate: 85%; the middle value lies on the limit itself.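

No step can be read from compound 3 to compound 4, because both values are limits of the assay rather than numbers: the limit of > 30000 nM in this assay, at which 4 of the 4 values shown sit.

The compounds shown leave open how strongly, if at all, any of them acts in this assay, and whether putting dimethylamino in place of the larger group changes that.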